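The source may hold more compounds than are shown below. What is called first, only, known or untested is meant among the compounds shown, and "the series" means these compounds.

Working notes on the series. Compound 1 `O=C(O)CCn1c(=O)oc2cc(Cl)c(Cl)cc21` has the highest number of the two measured compounds in an assay for inhibition of kynurenine 3-monooxygenase (Homo sapiens), read by mass spectrometry, with a stated time of 1 h (a higher number here means a weaker inhibitor, a lower number a stronger inhibitor), where compound 1 gives 6.31 nM. Going by the values given here, the other measured compound, compound 2 `Cc1ccc([C@@H](C)Oc2cc3onc(CCC(=O)O)c3cc2Cl)nn1`, gives 2 nM in this assay, a lower number than compound 1 by a gap that lies beyond the usual scatter; no single-point step links these two.

Compound 3 `CCOc1cc2oc(=O)n(CCC(=O)O)c2cc1Cl` is not yet measured. Against compound 1 it shows one change: ethoxy in place of chloro on an aromatic carbon. Compound 2 carries an alkoxy group on its aromatic ring with a chloro group ortho to it and gives the lower number of the pair, so an ethoxy group at a comparable place is expected to be tolerated. The step from compound 1 to compound 3 is therefore expected to be small, a 1.3-fold lower number from compound 1 to compound 3 (0.10 log units; within the scatter), not beyond the scatter. For compound 3 in this assay the estimate is 5 nM, within 1.5 nM to 20 nM.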

Compound 3, half-maximal inhibitory concentration: 5.01 nM
Compound 3: the middle estimate sits 1.0-fold (0.00 log units) below what was measured, within the range that was stated.
By their numbers in this assay, from the lowest: compound 2; then compounds 3 and 1 (each within the scatter of the next).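

Going by these compounds alone, the step in this assay is the first single-point reading at this position: ethoxy in place of chloro on this aromatic carbon, ortho to a chloro group, gives a 1.3-fold lower number from compound 1 to compound 3 (0.10 log units; within the scatter). Within the shared core, then, this carbon takes ethoxy, with 3 heavy atoms and 1 hydrogen-bond acceptor, in place of chloro, with 1 heavy atom and none, and the two compounds cannot be told apart in this measurement. No accompanying measurement accounts for this match between the two groups.

From the compounds shown here alone, how far this holds for other groups on the same carbon remains open, such as a longer chain like butoxy, a hydroxyl or an amine. Also open, going by these compounds, is whether ethoxy would read the same without the remaining chloro group.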